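The source may report more compounds than this note shows. Statements on the series, on what has been measured and on what is new or still open speak of the compounds shown alone.

Measured compounds:
- compound 1, `O=C(O)CCCCC1=CC[C@@H]2[C@@H](/C=C/[C@@H](O)COc3ccccc3)[C@H](O)C[C@@H]2OC1`: 73 nM
- compound 2, `O=C(O)CCCCCC1=CC[C@@H]2[C@@H](/C=C/[C@@H](O)COc3ccccc3)[C@H](O)C[C@@H]2OC1`: 880 nM
- compound 3, `O=C(O)CCC[C@@H]1CC[C@@H]2[C@@H](/C=C/[C@@H](O)COc3ccccc3)[C@H](O)C[C@@H]2OC1`: 280 nM

All three were run in a functional assay on CHO cells for agonist activity at prostaglandin F2-alpha receptor (Homo sapiens), read by fluorescence and calcium flux; on this read-out higher numbers stand for an effect only at larger amounts of compound and lower numbers for an effect already at smaller amounts. Compound 1 gives the lowest number of the three; compound 2 differs from it by carboxymethyl in place of carboxy on a saturated chain carbon, four bonds along the chain from a double-bonded ring carbon and the step is a 12-fold higher number from compound 1 to compound 2 (1.08 log units; beyond the scatter). Compound 3 rests on a different core; how its core differs from that of compound 1 is not broken down here. Its value in this assay stands between the other two.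

Compound 4, `O=C(O)CCCC[C@@H]1CC[C@@H]2[C@@H](/C=C/[C@@H](O)COc3ccccc3)[C@H](O)C[C@@H]2OC1`, is not yet measured. It differs from compound 3 by carboxymethyl in place of carboxy on a saturated chain carbon, three bonds along the chain from a saturated ring carbon. Going by the values given here, this is the same kind of change as the one from compound 1 to compound 2, though the place is not the same: there the chain carbon stands four bonds along the chain from a double-bonded ring carbon, here three bonds from a saturated ring carbon. Among the compounds with values here, the step from compound 3 to compound 4 in this assay is expected to be an 8.9-fold higher number from compound 3 to compound 4 (0.95 log units; beyond the scatter), resting on the one earlier example of this kind of change, a 12-fold higher number from compound 1 to compound 2 (1.08 log units; beyond the scatter), with the different core and place leaving room for a smaller step. Compound 4 is therefore estimated at 2500 nM, with a range from 900 nM to 7000 nM.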

Compound 4, half-maximal effective concentration: 110 nM
Beside the measured number, compound 4's estimate is 23-fold (1.36 log units) above it, and the stated range ends above it.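

In this assay, carboxymethyl in place of carboxy on the core of compound 3 gives a 2.5-fold lower number from compound 3 to compound 4 (0.41 log units; beyond the scatter), so the change does not carry from one core to the other in this series, not even in direction: the same change on two cores in this assay, a 12-fold higher number (1.08 log units; beyond the scatter) from compound 1 to compound 2 and a 2.5-fold lower number (0.41 log units; beyond the scatter) from compound 3 to compound 4, 31-fold (1.49 log units) apart, beyond the scatter of two such steps

This shows that a step seen on the core of compound 1 cannot be taken over as a guide on the core of compound 3. Going by these compounds alone, it does not show what lies behind the gap: the core and the place both differ, three bonds along the chain from a saturated ring carbon here and four bonds along the chain from a double-bonded ring carbon in the earlier step, and each core supplies only one pair.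

Open, going by these compounds, is how a longer chain than the 4-carboxybutyl of compound 4 behaves on either core. Also open, on these data alone, is whether an amide or a methyl ester in place of the carboxylic acid follows the same split between the cores.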